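Methoxy in Place of Fluoro: Expecting a Small Step

The source may report more compounds than this note shows. Statements on the series, on what has been measured and on what is new or still open speak of the compounds shown alone.

Of the compounds shown here, three have been measured in an ADME assay on microsomes from liver (Homo sapiens) for metabolic stability, tested at 2.5 uM; a lower number here means slower removal, a higher number faster removal of the compound. Compound 1 `COc1ccc(-c2c(S(=O)(=O)c3ccc(OC)cc3)cnc3cc(F)ccc23)cc1` gives 1.18 mL/min, compound 2 `COc1cccc(-c2c(S(=O)(=O)c3ccc(F)cc3)cnc3c(F)cccc23)c1` gives 2.23 mL/min, and compound 3 `COc1ccc(S(=O)(=O)c2cnc3cc(F)ccc3c2-c2ccc(F)cc2)cc1` gives 1.71 mL/min. Compound 3 and compound 1 differ in a single place: methoxy in place of fluoro on an aromatic carbon. That change made a step of a 1.4-fold lower number from compound 3 to compound 1 (0.16 log units; within the scatter). Compound 2 and compound 3 are built from the same atoms joined differently; the difference between their cores is not broken down here.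

Compound 4 `COc1ccc(S(=O)(=O)c2cnc3c(F)cccc3c2-c2cccc(OC)c2)cc1` has not yet been measured. It differs from compound 2 by the same change, (methoxy in place of fluoro on an aromatic carbon), at a place described in exactly the same words as before. Because the earlier step of a 1.4-fold lower number from compound 3 to compound 1 (0.16 log units; within the scatter) stayed within the scatter, the step expected here is of similar size: a 1.4-fold lower number from compound 2 to compound 4 (0.14 log units; within the scatter). This expectation rests on that one earlier pair alone, and nothing shows whether the change behaves alike on the core of compound 2. Compound 4 is therefore estimated at 1.6 mL/min in this assay, with a range expected from 1 mL/min to 2.6 mL/min.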

Compound 4, intrinsic clearance in a liver preparation (reported as CLH), per the amount of preparation that the assay uses: 2.87 mL/min
Beside the measured number, compound 4's estimate is 1.8-fold (0.25 log units) below it; the whole stated range lies below it.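

In this assay, the change from 4-fluorophenyl to 4-methoxyphenyl makes a step of a 1.3-fold higher number from compound 2 to compound 4 (0.11 log units; within the scatter). Set side by side, the steps on the two cores cannot be told apart, so in these two pairs the change carries over as a small step that stays inside the ordinary spread of repeated measurements: the same change on two cores in this assay, a 1.4-fold lower number (0.16 log units; within the scatter) from compound 3 to compound 1 and a 1.3-fold higher number (0.11 log units; within the scatter) from compound 2 to compound 4, 1.9-fold (0.27 log units) apart, within the scatter of two such steps Two pairs cannot show that the change behaves alike on every core in this series, and a small real difference between these two cores would stay hidden in the scatter.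

The compounds shown leave open what happens at this place with a group other than fluoro or methoxy, such as an amine, a carboxylic acid or a longer alkoxy chain. They also leave open how the same change behaves at other places on these molecules, and in any measurement other than this assay.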